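Swapping Ring Fluorines for a Methyl Group

The source may hold more compounds than are shown below. What is called first, only, known or untested is meant among the compounds shown, and "the series" means these compounds.

Compound 1, `N#Cc1cc(-c2nc(C(c3ccc(F)cc3)c3ccc(F)cc3)sc2CC(=O)O)ccc1F`, gives 57 nM in an in vitro assay on HEK385-7 cells for displacement of a labelled ligand from prostaglandin D2 receptor 2 (Homo sapiens); a higher number here means a weaker inhibitor, a lower number a stronger inhibitor.
Compound 2, `O=C(O)Cc1sc(C(c2ccc(F)cc2)c2ccc(F)cc2)nc1-c1ccnc(F)c1`, gives 0.48 nM in this assay.
Compound 3, `O=C(O)Cc1sc(C(c2ccc(F)cc2)c2ccc(F)cc2)nc1-c1cc(F)nc(F)c1`, gives 5.4 nM in this assay.

Compound 3 stands second highest of these three numbers. The nearer step is an 11-fold lower number from compound 1 to compound 3 (1.02 log units; beyond the scatter); the further one is an 11-fold higher number from compound 2 to compound 3 (1.05 log units; beyond the scatter). Both lie beyond the scatter.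

Compound 4, `Cc1cc(-c2nc(C(c3ccc(F)cc3)c3ccc(F)cc3)sc2CC(=O)O)ccn1`, has not been measured. It differs from compound 3 in one place: 2-methylpyridin-4-yl in place of 2,6-difluoropyridin-4-yl on an aromatic carbon. Among the compounds with values here, one measured step bears on this change, an 11-fold higher number from compound 2 to compound 3 (1.05 log units; beyond the scatter), where a single fluorine added to the pyridine ring raised the number sharply. Going from compound 3 to compound 4 removes one of those fluorines again and replaces the other with a methyl group; for the fluorine-to-methyl swap itself no measured step exists, so that part carries more uncertainty.

Compound 4 is therefore expected to give about 1 nM in this assay, with a likely range from 0.3 nM to 4 nM. The expected step is a 5.4-fold lower number from compound 3 to compound 4 (0.73 log units; beyond the scatter).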

Compound 4, half-maximal inhibitory concentration: 3.1 nM
The estimate for compound 4 lay 3.1-fold (0.49 log units) below the measured number; low and high end bracket the measured number.
By their numbers in this assay, from the lowest: compound 2; then compounds 4 and 3 (each within the scatter of the next); then compound 1.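

Replacing the single fluoro on the pyridine ring with methyl is not a neutral swap: this assay shows a 6.5-fold higher number from compound 2 to compound 4 (0.81 log units; beyond the scatter). Changing 2,6-difluoropyridin-4-yl to 2-methylpyridin-4-yl gives a 1.7-fold lower number from compound 3 to compound 4 (0.24 log units; within the scatter), so these two groups cannot be told apart at this position on the ring, even though they differ in their atoms. The methylpyridine also keeps most of the advantage over the 3-cyano-4-fluorophenyl group, with an 18-fold lower number from compound 1 to compound 4 (1.26 log units; beyond the scatter), so every pyridine shown here reads well below that phenyl group.

Nothing measured here explains these differences. Still open, going by these compounds, is how a chloro, methoxy or amino group would read in place of this methyl, and how the pyridin-4-yl ring would read with hydrogen there.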